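From 2-methylphenyl to 2-fluorophenyl

The source may hold more compounds than are shown below. What is called first, only, known or untested is meant among the compounds shown, and "the series" means these compounds.

Compound 1 (`Cc1ccc(N2CCN(C(=S)SCc3ccc4nc(N)nc(N)c4c3)CC2)cc1`): 2480 nM
Compound 2 (`Cc1ccccc1N1CCN(C(=S)SCc2ccc3nc(N)nc(N)c3c2)CC1`): 4230 nM
Compound 3 (`Nc1nc(N)c2cc(CSC(=S)N3CCN(c4ccccc4F)CC3)ccc2n1`): not yet measured

Compound 1 and compound 2 were both measured in a functional assay on MCF7 cells (Homo sapiens) for antiproliferative activity, read by MTT assay, with a stated time of 72 h (on this read-out higher numbers stand for weaker inhibition and lower numbers for stronger inhibition), and lie within the scatter of each other, with compound 2 at 4230 nM on this scale. The step to compound 3 turns 2-methylphenyl into 2-fluorophenyl (fluoro in place of methyl on an aromatic carbon): fluoro in place of methyl on an aromatic carbon, ortho to a large group. For the measured compounds named here, no measured pair exchanges methyl for fluoro, so the data give no direct size for this change. Going by the values given here, the only step that bears on it, and then only loosely, is a 1.7-fold higher number from compound 1 to compound 2 (0.23 log units; within the scatter) for 2-methylphenyl in place of 4-methylphenyl on an amine nitrogen in a ring, and that step lies within the scatter. On this slender evidence, no step beyond the scatter is expected in this assay in either direction. The estimated step (a 1.2-fold lower number from compound 2 to compound 3 (0.08 log units; within the scatter)) is expected to stay within the scatter. For compound 3 the expected value is 3500 nM with an estimated range from 1500 nM to 8000 nM in this read-out.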

Compound 3, half-maximal inhibitory concentration: 4840 nM
Beside the measured number, compound 3's estimate is 1.4-fold (0.14 log units) below it; measured number inside the range.
By their numbers in this assay, from the lowest: compounds 1, 2 and 3 (each within the scatter of the next).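

In this assay, 2-fluorophenyl in place of 2-methylphenyl gives a 1.1-fold higher number from compound 2 to compound 3 (0.06 log units; within the scatter), so fluoro and methyl on this aromatic carbon, ortho to a large group, read alike, something the earlier pair could not show, as it differed only in where the methyl sits. For the compounds shown here, putting 2-fluorophenyl in place of 4-methylphenyl on the same amine nitrogen gives a 2.0-fold higher number from compound 1 to compound 3 (0.29 log units; within the scatter), so this change of both group and place also stays within the scatter, and no step among the three compounds in this assay goes beyond it. No measurement at hand speaks to the cause of these small steps.

The compounds shown leave open whether any other group on this aromatic carbon, such as a methoxy group, a chlorine, an amine or a carboxylic acid, would give a step beyond the scatter. They also leave open whether the numbers would stay within the scatter if a longer chain separated the phenyl from the amine nitrogen.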